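Ethyl on the Carbamoyl Nitrogen and Cytotoxicity

This account rests on a few compounds, and the source may have more. Where it says the series, first, only, none or still open, it means among the compounds named here.

Three compounds have been measured in a functional assay on SMMC-7721 cells (Homo sapiens) for cytotoxicity, read by MTT assay, with a stated time of 72 h; on this read-out higher numbers stand for weaker inhibition and lower numbers for stronger inhibition:

Compound 1, `NC(=O)N1CCN(C(=S)SCc2cn(Cc3ccc(F)cc3)nn2)CC1`, gives > 128000 nM.
Compound 2, `CCNC(=O)N1CCN(C(=S)SCc2cn(Cc3ccc(F)cc3)nn2)CC1`, gives 44400 nM.
Compound 3, `NC(=O)N1CCN(C(=S)SCc2cn(Cc3ccc(Cl)cc3)nn2)CC1`, gives > 128000 nM.

The value of compound 1 is a limit of the assay, not a number. The value of compound 3 is likewise a limit; it sits at the limit of > 128000 nM in this assay, at which 2 of the 3 values shown sit.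

Compound 2 differs from compound 1 by ethyl in place of hydrogen on an amide-type nitrogen. This change produced an at least 2.8-fold lower number from compound 1 to compound 2 (0.45 log units; beyond the scatter). Compound 3 differs from compound 1 by chloro in place of fluoro on an aromatic carbon, and that gave a step that the two limits leave unreadable from compound 1 to compound 3.

Compound 4, `CCNC(=O)N1CCN(C(=S)SCc2cn(Cc3ccc(Cl)cc3)nn2)CC1`, is not yet measured. It differs from compound 3 by ethyl in place of hydrogen on an amide-type nitrogen, the same change as from compound 1 to compound 2, at the same kind of place. Compound 4 is expected to show an at least 2.8-fold lower number from compound 3 to compound 4 (0.45 log units; beyond the scatter), which rests on the step of an at least 2.8-fold lower number from compound 1 to compound 2 (0.45 log units; beyond the scatter) and on the value of compound 2, 44400 nM. For compound 4 the estimate in this assay is 45000 nM, with a range from 15000 nM to 130000 nM.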

Compound 4, half-maximal inhibitory concentration: > 128000 nM
Compound 4: only a limit was reported (the forecaster's own chance of this, stated with the estimate: 25%); middle value at least 2.8-fold (0.45 log units) from the limit.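

In this assay compound 4 gives > 128000 nM and this is a limit of the assay, not a number. Compound 3 stands at a limit as well, so the step of ethyl in place of hydrogen on the amide-type nitrogen cannot be read on the chloro core, and the series shows neither that the lower number seen on the fluoro core carries over nor that it is lost; most of the values shown sit at this same limit: the limit of > 128000 nM in this assay, at which 3 of the 4 values shown sit. What can be read is the exchange with the ethylcarbamoyl group kept, where chloro in place of fluoro gives an at least 2.8-fold higher number from compound 2 to compound 4 (0.45 log units; beyond the scatter) and the number seen with the fluoro core is not retained.

From the compounds shown here alone, with the ethyl change read only once, on the fluoro core, its transfer to other cores remains open. Going by these compounds, whether a longer chain such as propyl on the amide-type nitrogen, or a methoxy group in place of the halogen, would bring the chloro or fluoro compounds to a measurable number also stays open.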